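A few compounds are considered here, and "the series" means these few. Any claim that something is new, unique, unknown or untested is made for them only; others in the source may bear on it.

Measured compounds:
- Compound 1, `Oc1cccc(-c2cc(-c3ccc(F)cc3)cc(-c3cccc(O)c3)n2)c1`, a functional assay on T47D cells (Homo sapiens) for inhibition (a higher number here means a weaker inhibitor, a lower number a stronger inhibitor), 6870 nM
- Compound 2, `Oc1ccc(-c2cc(-c3ccccc3F)cc(-c3cccc(O)c3)n2)cc1`, this assay 6370 nM
- Compound 3, `Oc1ccc(-c2cc(-c3cccc(F)c3)cc(-c3cccc(O)c3)n2)cc1`, this assay 3510 nM

Compound 3 gives the lowest of the three numbers, but its nearest neighbour, compound 2, and its furthest, compound 1, both sit within the scatter of it, so none of the three can be set apart from the others.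

Compound 4 is `Oc1ccc(-c2cc(-c3ccc(F)cc3)cc(-c3cccc(O)c3)n2)cc1`. It differs from compound 3 only in the fluorine position: 4-fluorophenyl in place of 3-fluorophenyl on an aromatic carbon.

For the measured compounds named here, the one measured step that bears on moving the fluorine around the fluorophenyl ring is a 1.8-fold lower number from compound 2 to compound 3 (0.26 log units; within the scatter). Going by the values given here, compound 1 carries the same 4-fluorophenyl group as compound 4 but differs from compound 3 in the position of a hydroxyl as well, so no single step can be drawn from it; its value and that of compound 3 lie within the scatter of each other. Shifting the fluorine once more is therefore expected to give no step beyond the scatter, a 1.3-fold higher number from compound 3 to compound 4 (0.11 log units; within the scatter).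

Compound 4 is thus estimated at 4500 nM, with a range from 2000 nM to 10000 nM.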

Compound 4, half-maximal inhibitory concentration: 5000 nM
Compound 4: middle estimate off by 1.1-fold (0.05 log units), on the low side; measured number inside the range.
By their numbers in this assay, from the lowest: compounds 3, 4, 2 and 1 (each within the scatter of the next).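

With compound 4 included, the 2-fluorophenyl, 3-fluorophenyl and 4-fluorophenyl groups can all be compared on the same core: in this assay there is a 1.4-fold higher number from compound 3 to compound 4 (0.15 log units; within the scatter) and a 1.3-fold lower number from compound 2 to compound 4 (0.11 log units; within the scatter), so neither step to the 4-fluorophenyl group can be read as a real change. For the compounds shown here, compound 4 also provides a comparison that the earlier compounds lacked, a change in one place on a hydroxyl-bearing ring, with 4-hydroxyphenyl in place of 3-hydroxyphenyl; this gives a 1.4-fold lower number from compound 1 to compound 4 (0.14 log units; within the scatter), so this change also stays within the usual variation between repeats. No other measurement here bears on these results.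

As far as these compounds go, all four compounds carry a fluorophenyl group opposite the ring nitrogen, so it remains open whether a chlorophenyl, a methoxyphenyl or an unsubstituted phenyl group there would shift the number beyond the scatter. From the compounds shown here alone, it is equally open whether an aminophenyl group in place of either hydroxyphenyl group, or a carboxylic acid on that ring, would give a step that can be read.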